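This account rests on a few compounds, and the source may have more. Where it says the series, first, only, none or still open, it means among the compounds named here.

Measured so far:
compound 1 `COc1cc(-c2cc(-c3cc(C(C)C)c(O)cc3C)[nH]c(=O)c2C#N)cc(OC)c1OC` — 82%
compound 2 `COc1ccc(-c2cc(-c3cc(C(C)C)c(O)cc3C)[nH]c(=O)c2C#N)c(OC)c1` — 55%
compound 3 `COc1ccc(-c2cc(-c3cc(C(C)C)c(O)cc3C)[nH]c(=O)c2C#N)cc1` — 47.5%

In a functional assay for inhibition, tested at 80 ug/mL (a lower number here means a weaker effect, a higher number a stronger effect of the compound at the concentration tested), compound 3 gives the lowest of the three numbers; compound 2 lies within the scatter of it, compound 1 beyond it. Compound 4 `COc1ccc(-c2cc(-c3cc(C(C)C)c(O)cc3C)[nH]c(=O)c2C#N)cc1OC` differs from compound 3 by methoxy in place of hydrogen on an aromatic carbon. Among the measured compounds shown here, the one measured step of the same kind runs the other way: a number 7.5 percentage points lower from compound 2 to compound 3 (within the scatter), within the scatter. Compound 1, carrying two further methoxy groups, gives 82%, while compound 3 gives 47.5%. On this basis a modest rise is expected for compound 4, of about a number 12.5 percentage points higher from compound 3 to compound 4 (beyond the scatter), though a result within the scatter cannot be excluded. The estimate for compound 4 is 60%, in the range 46% to 76%.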

Compound 4, a percentage reported as inhibition, at one concentration (the size of the read-out at that concentration, not a potency): 58%
Compound 4: middle estimate off by 2 percentage points, on the high side; low and high end bracket the measured number.
By their numbers in this assay, from the lowest: compounds 3, 2 and 4 (each within the scatter of the next, the first and the last beyond it); then compound 1.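

In this assay, going from 4-methoxyphenyl to 3,4-dimethoxyphenyl gives a number 10.5 percentage points higher from compound 3 to compound 4 (beyond the scatter), so adding a methoxy group at this position can shift the read-out beyond the scatter. The placement of the second methoxy group does not separate the two dimethoxyphenyl compounds, with a number 3 percentage points higher from compound 2 to compound 4 (within the scatter). Removing a methoxy group gives a number 24 percentage points lower from compound 1 to compound 4 (beyond the scatter), and the size of this change depends on the starting compound: the same change on two cores in this assay, a number 7.5 percentage points lower (within the scatter) from compound 2 to compound 3 and a number 24 percentage points lower (beyond the scatter) from compound 1 to compound 4, 16.5 percentage points apart, beyond the scatter of two such steps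

Going by these compounds, whether the rise is specific to methoxy remains open. A hydroxyl, a fluorine or an ethoxy group at this position could answer that.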